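The source may hold more compounds than are shown below. What is called first, only, known or untested is meant among the compounds shown, and "the series" means these compounds.

In an ADME assay on J774.A1 cells (Mus musculus) for inhibition, read by MTT assay, with a stated time of 72 h (a higher number here means that more compound is needed for the effect, a lower number that less compound is needed), compound 1 `Cc1ccc(CNc2nc(NCc3ccccc3)nc3ccccc23)cc1` gives 2100 nM, and compound 2 `Cc1ccc(CNc2nc(NCc3ccccc3)c3ccccc3n2)cc1` gives 4500 nM. Going by the values given here, these two values are the only numbers available, and the two compounds carry different groups from the pair followed here. Compound 3 `c1coc(CNc2nc(NC3CCC3)nc3ccccc23)c1` has no position on the scale, since its entry reads "not determined" (no result reported). This means there is no starting value from which to measure a step.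

The next compound to be tested is compound 4 `c1coc(CNc2nc(NC3CCCCC3)nc3ccccc23)c1`. The structural change is cyclohexyl in place of cyclobutyl on a nitrogen on an aromatic ring, which puts cyclohexyl in place of cyclobutyl on a nitrogen on an aromatic ring. Among the compounds with values here, no measured pair shows what a change at this place does, so the expectation is cautious: no step beyond the usual scatter, in either direction. The nearest guide to the likely range is therefore the pair of values from compound 1 at 2100 nM and compound 2 at 4500 nM. For compound 4 the expected value is 5000 nM, with an estimated range from 1500 nM to 20000 nM.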

Compound 4, half-maximal effective concentration: 5300 nM
Beside the measured number, compound 4's estimate is 1.1-fold (0.03 log units) below it, and the stated range covers the measured number.
By their numbers in this assay, from the lowest: compound 1; then compounds 2 and 4 (each within the scatter of the next).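

No step can be read between compound 3 and compound 4, as compound 3 has no number in this assay. What cyclohexyl in place of cyclobutyl does to the value stays open, and nothing shown offers an explanation for the value of compound 4.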